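Swapping a benzothiophene for a fluorinated anilide arm

This account rests on a few compounds, and the source may have more. Where it says the series, first, only, none or still open, it means among the compounds named here.

Of the compounds shown here, three have been tested in an assay on isolated protein for inhibition of MAP kinase-activated protein kinase 2 (Homo sapiens), read by HTRF, tested at 10 uM; a higher number here means more inhibition at the concentration tested (going by the name of the read-out), a lower number less inhibition. Compound 1, `Cc1cccc(Oc2ccnc(N3CCN(C(=O)c4c(C)noc4C)CC3)n2)c1`, gives 0%. Compound 2, `Cc1cccc(Oc2ccnc(N3CCC[C@H]3C(=O)NCCCn3ccnc3)n2)c1`, gives 2%. Compound 3, `Clc1ccc2sc(CN3CCN(c4ncnc5c4CN(Cc4ccccc4)CC5)CC3)cc2c1`, gives 1%. All three numbers sit within the usual scatter of one another, so none of them can be said to be higher or lower than the rest; compound 3 lies within the scatter of both compound 1 and compound 2, and the inhibition numbers in this assay are level across the set.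

Compound 4, `O=C(CN1CCN(c2ncnc3c2CN(Cc2ccccc2)CC3)CC1)Nc1cc(F)ccc1F`, has not yet been measured. It keeps the shared core of compound 3 and differs only in one arm: (2,5-difluorophenyl)carbamoyl in place of 5-chloro-1-benzothiophen-2-yl on a saturated chain carbon bound to an amine nitrogen in a ring. Among the compounds with values here, no pair of measured compounds differing in a single place has been recorded, so there is nothing to indicate how large a step such a change produces in this assay. Since compound 3 shows 1% and the other two compounds show the same picture, the expectation for compound 4 is a step of a number 2 percentage points higher from compound 3 to compound 4 (within the scatter), that is, no change beyond the scatter. Compound 4 is therefore estimated to give 3%, with a range from 0% to 15%.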

Compound 4, a percentage reported as inhibition, at one concentration (the size of the read-out at that concentration, not a potency): 0%
Beside the measured number, compound 4's estimate is 3 percentage points above it, and the stated range covers the measured number.
By their numbers in this assay, from the lowest: compounds 1, 4, 3 and 2 (each within the scatter of the next).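

Within the data shown here, this is the first pair in the set that differs in one place, so the arm on a saturated chain carbon bound to an amine nitrogen in a ring can now be read directly: in this assay, (2,5-difluorophenyl)carbamoyl in place of 5-chloro-1-benzothiophen-2-yl gives a number 1 percentage points lower from compound 3 to compound 4 (within the scatter). Two arms that differ in their rings and atoms, one of them bringing a carbonyl and an amide hydrogen, therefore leave the read-out level at this position. No measurement on hand explains this result.

From the compounds shown here alone, whether any arm at this place can move the number beyond the scatter stays open, for example a carboxylic acid or a primary amine on a longer chain. Also open, going by these compounds, is whether changing the shared core would alter the read-out.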